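Three Anilide Analogues and a Morpholine Amide Awaiting Measurement

A few compounds are considered here, and "the series" means these few. Any claim that something is new, unique, unknown or untested is made for them only; others in the source may bear on it.

Three compounds share one core, a nitro-bearing bicyclic head joined through a sulfur-linked six-carbon chain to an ester, then to a short acid chain ending in an amide. Compound 1 `O=C(CCC(=O)OCCCCCCSc1ccc([N+](=O)[O-])c2nonc12)Nc1ccccc1Cl` carries a 2-chlorophenyl on the amide nitrogen and in a functional assay on A549 cells (Homo sapiens) for inhibition, read by MTT assay, with a stated time of 72 h (on this read-out higher numbers stand for weaker inhibition and lower numbers for stronger inhibition), compound 1 gives 2750 nM. Compound 2 `O=C(CCC(=O)OCCCCCCSc1ccc([N+](=O)[O-])c2nonc12)Nc1cccc(Cl)c1` carries a 3-chlorophenyl there; in this assay compound 2 gives 5290 nM, and the step of a 1.9-fold higher number from compound 1 to compound 2 (0.28 log units; within the scatter). Compound 3 `Cc1ccc(NC(=O)CCC(=O)OCCCCCCSc2ccc([N+](=O)[O-])c3nonc23)cc1` carries a 4-methylphenyl and in this assay compound 3 gives 5240 nM. Among these three numbers compound 3 sits second highest, the step of a 1.0-fold lower number from compound 2 to compound 3 (0.00 log units; within the scatter) and the step of a 1.9-fold higher number from compound 1 to compound 3 (0.28 log units; within the scatter). So the three anilides are indistinguishable within the scatter.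

Compound 4 `O=C(CCC(=O)N1CCOCC1)OCCCCCCSc1ccc([N+](=O)[O-])c2nonc12` makes a different kind of change: morpholin-4-yl in place of (4-methylphenyl)amino on a carbonyl carbon. Among the measured compounds shown here, no measured step swaps the aromatic ring for a non-aromatic one, so none bears directly on it; the only guidance is that varying the ring on this amide so far moved nothing beyond the scatter. Compound 4 is therefore expected to stay near compound 3, the step of a 1.2-fold higher number from compound 3 to compound 4 (0.09 log units; within the scatter) being the estimate, with compound 4 at about 6500 nM, plausibly between 2500 nM and 17000 nM.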

Compound 4, half-maximal inhibitory concentration: 1670 nM
Beside the measured number, compound 4's estimate is 3.9-fold (0.59 log units) above it, and the stated range ends above it.
By their numbers in this assay, from the lowest: compounds 4, 1, 3 and 2 (each within the scatter of the next, the first and the last beyond it).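

Among the compounds shown here, replacing the anilide ring with morpholin-4-yl on this carbonyl carbon gives the first steps that go beyond the scatter in this assay (by a 3.1-fold lower number from compound 3 to compound 4 (0.50 log units; beyond the scatter) and by a 3.2-fold lower number from compound 2 to compound 4 (0.50 log units; beyond the scatter)), both modest and both towards stronger inhibition. The gain does not hold against every anilide, as compound 1 stays within the scatter of the morpholine amide (by a 1.6-fold lower number from compound 1 to compound 4 (0.22 log units; within the scatter)), so this position tolerates a non-aromatic ring without loss but is not shown to be clearly better with one. Nothing measured here explains the shift.

Still open, on these data alone, is whether the ring oxygen of morpholin-4-yl matters, which a piperidin-1-yl group would test. Also open, as far as these compounds go, is whether losing the amide hydrogen alone is enough, which a methyl group on the anilide nitrogen would test.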